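The compounds below may be only part of what the source reports. "The series", "measured", "known", "first", "only" and "open" are said of these compounds alone.

In a functional assay on HeLa cells (Homo sapiens) for antiproliferative activity, read by sulforhodamine B assay (on this read-out higher numbers stand for weaker inhibition of growth and lower numbers for stronger inhibition of growth), compound 1 (`CC[C@@H]1O[C@H](COCc2ccccc2)[C@@H](OCc2ccccc2)[C@H](OCc2ccccc2)[C@H]1OC(C)=O`) gives > 50000 nM as a limit of the assay and not as a number. Compound 2 (`CCC[C@@H]1O[C@H](COCc2ccc3ccccc3c2)[C@@H](OCc2ccc3ccccc3c2)[C@H](OCc2ccc3ccccc3c2)[C@H]1O`) gives > 50000 nM as a limit too. Compound 3 (`CCCC[C@@H]1O[C@H](COCc2ccccc2)[C@@H](OCc2ccccc2)[C@H](OCc2ccccc2)[C@H]1O`) gives > 50000 nM as a limit as well, so it has no exact position on the scale. What can be said of compound 3 is thus the limit of > 50000 nM in this assay, at which 3 of the 3 values shown sit, and nothing finer.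

Compound 4 (`O[C@@H]1[C@@H](OCc2ccccc2)[C@H](OCc2ccccc2)[C@@H](COCc2ccccc2)O[C@H]1CC1CC1`) differs from compound 3 by one change (cyclopropyl in place of propyl on a saturated chain carbon bound to a saturated ring carbon) with cyclopropyl in place of propyl on a saturated chain carbon bound to a saturated ring carbon. Going by the values given here, no pair of measured compounds yet shows how large a single change can be here, so no shift beyond the usual scatter is expected in either direction. The step expected in this assay is a number no higher from compound 3 to compound 4 (the limit leaves the size open) as an estimate only. The estimate for compound 4 is 50000 nM with an expected range from 20000 nM to 100000 nM and a good chance that it will come out as a limit only.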

Compound 4, concentration for 50% growth inhibition: > 50000 nM
Compound 4: no number, only a limit; the forecaster's own chance of this, stated with the estimate: 85%; the middle value lies on the limit itself.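

No step can be read between compound 3 and compound 4 in this assay, because both values stop at the same limit: the limit of > 50000 nM in this assay, at which 4 of the 4 values shown sit.

The compounds shown leave open how strongly any of them inhibits growth, and whether cyclopropyl in place of propyl changes that at all.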